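A few compounds are considered here, and "the series" means these few. Any claim that something is new, unique, unknown or untested is made for them only; others in the source may bear on it.

The measured compounds are compound 1 `Cc1nn(C2COC2)cc1Nc1nc(N)c2c(C#N)c(N3CCC[C@H]3C)n(C)c2n1`, compound 2 `Cc1nn(C2CCOC2)cc1Nc1nc(N)c2c(C#N)c(N3CCC[C@H]3C)n(C)c2n1` and compound 3 `C[C@@H]1CCCN1c1c(C#N)c2c(N)nc(Nc3cn(C)nc3Cl)nc2n1C`. In an assay on isolated protein for inhibition of Leucine-rich repeat serine/threonine-protein kinase 2 (Homo sapiens), read by TR-FRET and LanthaScreen, with stated times of 50 min and 30 min, in the presence of a further agent that is not named here (on this read-out higher numbers stand for weaker inhibition and lower numbers for stronger inhibition), compound 1 gives 38 nM, compound 2 gives 19 nM; 44 nM (2 entries), and compound 3 gives 34 nM.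

Compound 3 holds the lowest of the two single numbers in this assay, but its nearest neighbour is compound 1, and the step of a 1.1-fold lower number from compound 1 to compound 3 (0.05 log units; within the scatter) lies within the scatter, so the two cannot be put in order. Compound 2 contributes a further entry without a single number; its repeats the several entries of compound 2 in this assay, 19 nM; 44 nM (2 entries) show how far one compound can move on repetition in this assay.

The unmeasured compound 4 `Cc1n[nH]cc1Nc1nc(N)c2c(C#N)c(N3CCC[C@H]3C)n(C)c2n1` differs from compound 3 by 3-methyl-1H-pyrazol-4-yl in place of 3-chloro-1-methyl-1H-pyrazol-4-yl on a nitrogen on an aromatic ring. Going by the values given here, one measured step bears on this place, the exchange of the whole pyrazole group a 1.1-fold lower number from compound 1 to compound 3 (0.05 log units; within the scatter), which left the number unchanged within the scatter. Among the compounds with values here, compound 4 keeps the methyl-bearing pyrazole of compound 1 and carries a hydrogen on the pyrazole nitrogen where compound 3 carries a methyl, a change for which no measured pair gives a direct reading. The two pyrazoles already tried in this assay gave numbers within the scatter of each other, and on that basis the account expects a step of a 1.3-fold higher number from compound 3 to compound 4 (0.12 log units; within the scatter) of no more than the scatter, with a wide range to cover the untested free ring nitrogen. For compound 4 in this assay the expected value is 45 nM, with a range from 15 nM to 140 nM.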

Compound 4, half-maximal inhibitory concentration: 42 nM
Beside the measured number, compound 4's estimate is 1.1-fold (0.03 log units) above it; low and high end bracket the measured number.
By their numbers in this assay, from the lowest: compounds 3, 1 and 4 (each within the scatter of the next).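

Compound 4 gives a reading in one place on the aromatic nitrogen of the pyrazole: with hydrogen in place of oxetan-3-yl, this assay shows a 1.1-fold higher number from compound 1 to compound 4 (0.04 log units; within the scatter). Going by these compounds alone, the exchange of the whole group, 3-methyl-1H-pyrazol-4-yl in place of 3-chloro-1-methyl-1H-pyrazol-4-yl on a nitrogen on an aromatic ring, gives a 1.2-fold higher number from compound 3 to compound 4 (0.09 log units; within the scatter), so three different pyrazole groups at this place now stand within the scatter of one another, and the free ring nitrogen, which the earlier compounds did not carry, sets no order among them. The scale for reading both steps is how far one compound can move on repetition: the several entries of compound 2 in this assay, 19 nM; 44 nM (2 entries)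

On these data alone, what remains open is whether an amine, a carboxylic acid or a longer alkyl chain on that pyrazole nitrogen would carry the number beyond the scatter in this assay. Also open is how the chlorine and the methyl on the pyrazole compare on their own, with the group on the ring nitrogen held the same, since the steps shown here change these together or leave the chlorine out.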